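The compounds below may be only part of what the source reports. "The series", "measured", "known", "first", "only" and "open" are said of these compounds alone.

Measured compounds:
- compound 1 `C=C(Br)C(=O)Nc1cccc(/C=C2\SC(=O)N(Cc3ccc(Cl)cc3)C2=O)c1` gives 1400 nM
- compound 2 `Nc1cccc(/C=C2\SC(=O)N(Cc3cccc(F)c3)C2=O)c1` gives 250000 nM
- compound 3 `Nc1ccc(/C=C2\SC(=O)N(Cc3ccc(F)cc3)C2=O)cc1` gives 111000 nM

These three numbers come from a functional assay on CCRF-CEM cells (Homo sapiens) for cytotoxicity, read by cell counting, with a stated time of 3 days; a lower number here means a stronger inhibitor, a higher number a weaker inhibitor. Compound 1 stands lowest of the three, and both gaps are beyond the scatter: compound 3 is the nearest to it, compound 2 the furthest. Going by the values given here, compounds 2 and 3 carry a free amine where compound 1 carries the bromoacrylamide, and no single-change step between measured compounds is available, so the two weaker values can only be noted, not traced to one change.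

The step of interest goes from compound 1 to compound 4 `C=C(Br)C(=O)Nc1cccc(/C=C2\SC(=O)N(Cc3ccccc3)C2=O)c1`, which has not yet been tested in this assay. The difference is hydrogen in place of chloro on an aromatic carbon, that is, 4-chlorobenzyl to benzyl. Among the compounds with values here, with no measured pair showing this change, the expectation rests on compound 1 alone, whose value of 1400 nM is the reference. The step from compound 1 to compound 4 is expected to be small, likely toward a slightly higher number, and possibly within the scatter: a 1.8-fold higher number from compound 1 to compound 4 (0.25 log units; within the scatter). Compound 4 is therefore expected at 2500 nM, within a range of 900 nM to 7000 nM.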

Compound 4, half-maximal inhibitory concentration: 510 nM
The estimate for compound 4 lay 4.9-fold (0.69 log units) above the measured number; the measured number lies below the stated range.
By their numbers in this assay, from the lowest: compound 4; then compound 1; then compound 3; then compound 2.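

In this assay, hydrogen in place of chloro on the aromatic carbon para to a large group gives a 2.7-fold lower number from compound 1 to compound 4 (0.44 log units; beyond the scatter), a modest step beyond the scatter, and this is the first single-change comparison among these compounds. With the bromoacrylamide kept, the chloro is therefore not required for a number in this range, and its removal moves the value down rather than up. Nothing available accounts for the direction of this step.

On these data alone, with only chloro and hydrogen compared directly at this position, it remains open how a methyl, a methoxy or a carboxylic acid there would read. Compounds 2 and 3 carry fluorine on the benzyl group but also a free amine in place of the bromoacrylamide, so they cannot show how fluoro compares with chloro or hydrogen here.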